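Terminal ethynyl on the side chain of compound 3

This account rests on a few compounds, and the source may have more. Where it says the series, first, only, none or still open, it means among the compounds named here.

For the measured compounds named here, compound 3 `C=CCc1cc(C(C)=O)c(O)cc1OCCCCCCC` sits at the bottom of the three numbers so far: in an assay on isolated protein for inhibition of leukotriene B4 receptor 1 (Homo sapiens), tested at 10 uM (on this read-out higher numbers stand for more inhibition at the one concentration tested (going by the name of the read-out) and lower numbers for less inhibition), compound 3 gives 31%. Its nearest neighbour is compound 2 `C=CCc1cc(C(C)=O)c(O)cc1OCCCCCCCC#N`, which in this assay gives 88%, and furthest away stands compound 1 `C=CCc1cc(C(C)=O)c(O)cc1OCCCCC#N`, which in this assay gives 92%. The two steps that end at compound 3 are both large: a number 61 percentage points lower from compound 1 to compound 3 (beyond the scatter) and a number 57 percentage points lower from compound 2 to compound 3 (beyond the scatter), while a number 4 percentage points lower from compound 1 to compound 2 (within the scatter).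

Compound 4 `C#CCCCCOc1cc(O)c(C(C)=O)cc1CC=C` differs from compound 3 in one place: ethynyl in place of propyl on a saturated chain carbon, four bonds along the chain from an oxygen on an aromatic ring. Going by the values given here, the chain that enters carries one triple bond outside aromatic rings, as the cyano of compound 1 does, yet it is ethynyl and not cyano, so none of the measured steps covers exactly this change. The measured steps show only that propyl or hydrogen at this chain position gives a far lower number than cyano; whether a triple bond alone recovers part of that is not known from the three compounds.

Compound 4 is therefore expected to land between the two extremes, with a number 24 percentage points higher from compound 3 to compound 4 (beyond the scatter) as the expected step in this assay. The estimate for compound 4 is 55%, within a range from 25% to 85%.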

Compound 4, a percentage reported as inhibition, at one concentration (the size of the read-out at that concentration, not a potency): 74%
Beside the measured number, compound 4's estimate is 19 percentage points below it; the range from low to high includes it.
By their numbers in this assay, from the lowest: compound 3; then compound 4; then compounds 2 and 1 (each within the scatter of the next).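

In this assay, for the compounds shown here, the step from the saturated chain to ethynyl is large, with a number 43 percentage points higher from compound 3 to compound 4 (beyond the scatter) showing that cyano is not the only group at this place that lifts the number well clear of compound 3. The lift is only partial, though, since the piece also reads a number 18 percentage points lower from compound 1 to compound 4 (beyond the scatter) and a number 14 percentage points lower from compound 2 to compound 4 (beyond the scatter) as modest steps, so ethynyl does not match either nitrile-bearing chain in this assay. Across the four compounds, all three chains with a triple bond outside aromatic rings stand above the saturated chain, and none goes against this, but the nitrile chains stay ahead of the ethynyl chain.

The compounds shown leave open whether a chain ending in a double bond, an amine or a carboxylic acid would keep the number up at this place. They also leave open whether a longer chain ending in ethynyl would hold its number as the longer nitrile chain of compound 2 does. Nothing available explains why ethynyl recovers so much of the number yet stays short of cyano.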